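A few compounds are considered here, and "the series" means these few. Any claim that something is new, unique, unknown or untested is made for them only; others in the source may bear on it.

In an ADME assay on NIH3T3 cells (Mus musculus) for cytotoxicity, read by MTT assay, with a stated time of 24 h (a higher number here means a weaker inhibitor, a lower number a stronger inhibitor), compound 1 (`O=C(CSc1nnc(-c2ccncc2)o1)N/N=C/c1ccc(F)cc1`) gives 170000 nM with a fluoro group on the aromatic ring, compound 2 (`O=C(CSc1nnc(-c2ccncc2)o1)N/N=C/c1ccc([N+](=O)[O-])cc1`) gives 195000 nM with a nitro group there, and compound 3 (`COc1ccc(/C=N/NC(=O)CSc2nnc(-c3ccncc3)o2)cc1`) gives 132000 nM with a methoxy group there. These numbers sit close together, and compound 3 cannot be told apart from the other two, as a 1.3-fold lower number from compound 1 to compound 3 (0.11 log units; within the scatter) and a 1.5-fold lower number from compound 2 to compound 3 (0.17 log units; within the scatter) make clear. Exchanging fluoro for nitro tells the same story, with a 1.1-fold higher number from compound 1 to compound 2 (0.06 log units; within the scatter) as the result.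

Compound 4 (`COc1cccc(/C=N/NC(=O)CSc2nnc(-c3ccncc3)o2)c1`) has the same atoms as compound 3, joined differently, with 3-methoxyphenyl in place of 4-methoxyphenyl on a carbon with a double bond to nitrogen. Among the compounds with values here, no measured pair shows this exact change, so the evidence is indirect. It rests on the three exchanges of one group for another at the ring, all of which stayed within the scatter. On that basis, the estimated step is a 1.1-fold higher number from compound 3 to compound 4 (0.06 log units; within the scatter) and no step beyond the scatter is expected in either direction. Compound 4 is estimated at 150000 nM with a range from 90000 nM to 250000 nM as the expected span.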

Compound 4, half-maximal inhibitory concentration: 179000 nM
The estimate for compound 4 lay 1.2-fold (0.08 log units) below the measured number; measured number inside the range.
By their numbers in this assay, from the lowest: compounds 3, 1, 4 and 2 (each within the scatter of the next).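

In this assay, the exchange of 4-methoxyphenyl for 3-methoxyphenyl keeps the same atoms and changes only how they are joined, and the result is a 1.4-fold higher number from compound 3 to compound 4 (0.13 log units; within the scatter) for this change. So at this place on the carbon with a double bond to nitrogen, moving the methoxy group produces no difference that can be told from repeat-measurement noise, which the earlier exchanges of one group for another could not show. Compound 4 is also indistinguishable from the compounds carrying other groups, with a 1.1-fold lower number from compound 2 to compound 4 (0.04 log units; within the scatter) and a 1.1-fold higher number from compound 1 to compound 4 (0.02 log units; within the scatter) as the two steps, and no information is available to explain why the numbers stay so close.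

Going by these compounds, all four compounds carry a methoxy, fluoro or nitro group on the aromatic ring, so it remains open whether an amine, a carboxylic acid or a longer chain there would give a step beyond the scatter. The compounds shown also leave open whether any change to the shared core would matter more than these changes on the ring.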